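Swapping the Bromophenyl Group of Compound 1

This account rests on a few compounds, and the source may have more. Where it says the series, first, only, none or still open, it means among the compounds named here.

In a functional assay on A549 cells (Homo sapiens) for antiproliferative activity, read by MTT assay (a lower number here means a stronger inhibitor, a higher number a weaker inhibitor), compound 1 `O=[N+]([O-])c1ccc(Nc2nccc(-c3ccc(Br)cc3)n2)cc1` gives 76000 nM. Compound 3 `COc1cccc(Nc2nccc(-c3ccc(Br)cc3)n2)c1` gives 82700 nM, which lies within the scatter of the value for compound 1, so the two stand level at the high end of the three numbers. Compound 2 `Clc1ccc(Nc2nccc(-c3ccc(Br)cc3)n2)cc1` stands well apart from them at 6110 nM.

The unmeasured compound 4 `O=[N+]([O-])c1ccc(Nc2nccc(-c3ccc(Cl)cc3Cl)n2)cc1` keeps the nitro group of compound 1 and changes a different part of the molecule, with 2,4-dichlorophenyl in place of 4-bromophenyl on an aromatic carbon.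

Among the measured compounds shown here, only one measured step exists to compare with this change. It is the large step of a 12-fold lower number from compound 1 to compound 2 (1.09 log units; beyond the scatter), seen when chloro replaces nitro. That step shows that a single swap can move the number a long way in this small set, but it concerns the nitro group, which compound 4 retains. For the measured compounds named here, no measured compound varies the 4-bromophenyl group, so the data give no firm direction, and no step beyond the scatter is expected. The estimated change is a 1.5-fold lower number from compound 1 to compound 4 (0.18 log units; within the scatter), and it carries real uncertainty. For compound 4 the expected value is 50000 nM, with an estimated range from 12000 nM to 150000 nM.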

Compound 4, half-maximal inhibitory concentration: 119000 nM
Estimate against measurement, compound 4: 2.4-fold (0.38 log units) below; measured number inside the range.
By their numbers in this assay, from the lowest: compound 2; then compounds 1, 3 and 4 (each within the scatter of the next).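

Among the compounds shown here, this is the first measured change at the aromatic carbon of the shared core that carries the 4-bromophenyl group. In this assay, placing 2,4-dichlorophenyl there gives a 1.6-fold higher number from compound 1 to compound 4 (0.19 log units; within the scatter) and the two compounds stand level, so this swap, with the nitro group kept, shows no measurable effect on the number. The large step seen with chloro in place of nitro, a 12-fold lower number from compound 1 to compound 2 (1.09 log units; beyond the scatter), has no counterpart at this position, and nothing measured here gives a reason for the result.

The compounds shown pair 2,4-dichlorophenyl only with the nitro group, so it remains open whether the same swap would also leave the number level when made on compound 2, which carries chloro and has the lowest number of the set. From the compounds shown here alone, it also remains open how a quite different group on this aromatic carbon, such as an amine, a carboxylic acid or a plain phenyl ring with no chlorine or bromine, would behave in this assay.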